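The source may report more compounds than this note shows. Statements on the series, on what has been measured and on what is new or still open speak of the compounds shown alone.

Compound 1 `C/C(=C\c1ccc(-c2ccc(C)cc2)o1)C(N)=O` and compound 2 `C/C(=C\c1ccc(-c2ccc(F)cc2)o1)C(N)=O` share one core; compound 3 `C/C(=C\c1cc(-c2ccc(C)cc2)cs1)C(N)=O` and compound 4 `C/C(=C\c1cc(-c2ccc(F)cc2)cs1)C(N)=O` share another, and the difference between the two cores is not broken down here. In a functional assay on MCF7 cells (Homo sapiens) for cytotoxicity, read by CCK-8 assay, with a stated time of 24 h (a lower number here means a stronger inhibitor, a higher number a weaker inhibitor), compound 1 gives only a limit, > 50000 nM. In this assay compound 2 gives 970 nM. The change between them, (fluoro in place of methyl on an aromatic carbon), produced an at least 51-fold lower number from compound 1 to compound 2 (1.71 log units; beyond the scatter). Compound 3 likewise gives only a limit in this assay, > 50000 nM. Compound 4 carries the same change, (fluoro in place of methyl on an aromatic carbon). The step expected in this assay is an at least 16-fold lower number from compound 3 to compound 4 (1.22 log units; beyond the scatter), resting on an at least 51-fold lower number from compound 1 to compound 2 (1.71 log units; beyond the scatter), though the starting point here is uncertain because of the limit of > 50000 nM in this assay, at which 2 of the 3 values shown sit. Compound 4 is therefore expected to give about 3000 nM in this assay, most likely between 300 nM and 50000 nM.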

Compound 4, half-maximal inhibitory concentration: 1440 nM
Beside the measured number, compound 4's estimate is 2.1-fold (0.32 log units) above it; the measured number falls inside the stated range.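

In this assay, fluoro in place of methyl on an aromatic carbon again gives an at least 34-fold lower number from compound 3 to compound 4 (1.54 log units; beyond the scatter), so on both cores shown the change goes the same way and lies beyond the scatter: the same change on two cores in this assay, an at least 51-fold lower number (1.71 log units; beyond the scatter) from compound 1 to compound 2 and an at least 34-fold lower number (1.54 log units; beyond the scatter) from compound 3 to compound 4; the limit leaves it open whether they differ. On these data alone, how large either step really is stays unknown, since each starts from a limit rather than a number: the limit of > 50000 nM in this assay, at which 2 of the 4 values shown sit. Two cores do not show that the change would carry to any further core in this series.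

The compounds shown leave open how chloro, methoxy or an amine at the same place would read in this assay. They also leave open what replacing the primary amide with a carboxylic acid would do on either core.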